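From a 4-cyanophenyl amide to a pyridin-2-yl amide

This account rests on a few compounds, and the source may have more. Where it says the series, first, only, none or still open, it means among the compounds named here.

Of the compounds shown here, three that share one core have been measured in a functional assay on MGC-803 cells (Homo sapiens) for inhibition, read by MTT assay, with a stated time of 72 h; a lower number here means a stronger inhibitor, a higher number a weaker inhibitor. Compound 1 `CCCc1ccc(NC(=O)C2CCN(C/C=C/c3ccccc3)CC2)cc1` gives 5210 nM, compound 2 `COc1cccc(NC(=O)C2CCN(C/C=C/c3ccccc3)CC2)c1` gives 37200 nM, and compound 3 `N#Cc1ccc(NC(=O)C2CCN(C/C=C/c3ccccc3)CC2)cc1` gives 28200 nM. Compound 3 therefore sits with compound 2 on the weaker side of the set, and the two cannot be told apart: a 1.3-fold lower number from compound 2 to compound 3 (0.12 log units; within the scatter). The next compound, compound 4 `O=C(Nc1ccccn1)C1CCN(C/C=C/c2ccccc2)CC1`, has pyridin-2-yl in place of 4-cyanophenyl on an amide-type nitrogen.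

Going by the values given here, no measured compound carries pyridin-2-yl, so the evidence is indirect. All three measured steps change the aromatic group on this nitrogen. Among the compounds with values here, two of them start from compound 1, the only one with a propyl group, and both are modest: a 7.1-fold higher number from compound 1 to compound 2 (0.85 log units; beyond the scatter) and a 5.4-fold higher number from compound 1 to compound 3 (0.73 log units; beyond the scatter). Compound 4 has no propyl group either, so it is expected to resemble compound 2 and compound 3, whose step stays within the scatter. No step beyond the scatter is therefore expected in this assay, only an estimated 1.1-fold higher number from compound 3 to compound 4 (0.03 log units; within the scatter). The expected value for compound 4 is 30000 nM, with an estimated range from 12000 nM to 75000 nM.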

Compound 4, half-maximal inhibitory concentration: 45200 nM
Estimate against measurement, compound 4: 1.5-fold (0.18 log units) below, and the stated range covers the measured number.
By their numbers in this assay, from the lowest: compound 1; then compounds 3, 2 and 4 (each within the scatter of the next).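

In this assay the step to a ring with a hetero atom gives a 1.6-fold higher number from compound 3 to compound 4 (0.20 log units; within the scatter) and the step from the other weak aryl amide gives a 1.2-fold higher number from compound 2 to compound 4 (0.08 log units; within the scatter), so 4-cyanophenyl, 3-methoxyphenyl and pyridin-2-yl on the amide-type nitrogen cannot be told apart here, even though these groups differ in ring atoms, in size and in the presence of a triple bond. Going by these compounds alone, only compound 1 stands apart, with an 8.7-fold higher number from compound 1 to compound 4 (0.94 log units; beyond the scatter) as its third step beyond the scatter, which leaves 4-propylphenyl as the one group of the four whose number separates from the rest at this position. Nothing available explains why these three groups read alike or why 4-propylphenyl differs from them.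

The compounds shown leave open whether the separation of compound 1 belongs to the propyl chain itself, and whether a longer chain such as butyl or pentyl in its place would widen the gap. They also leave open whether a pyridin-2-yl ring carrying a propyl group would read like compound 1 or like compound 4 , and how an amine or a carboxylic acid on the aromatic ring would read.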